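The source may report more compounds than this note shows. Statements on the series, on what has been measured and on what is new or still open speak of the compounds shown alone.

Measured so far:
- compound 1 `COc1cc(-c2nnsc2-c2ccc(F)cc2)cc(OC)c1OC`: "not determined" (no result reported)
- compound 2 `COc1ccc(-c2snnc2-c2cc(OC)c(OC)c(OC)c2)cc1`: 14.5 nM

Within the data shown here, in a functional assay on HL-60 cells (Homo sapiens) for antiproliferative activity (on this read-out lower numbers stand for stronger inhibition and higher numbers for weaker inhibition), compound 2 gives 14.5 nM, the only number in the set; compound 1 has no result, so no step between measured compounds can be drawn. Compound 3 `COc1cc(-c2nnsc2-c2ccc(Cl)cc2)cc(OC)c1OC` is the next entry. It differs from compound 2 in one place: chloro in place of methoxy on an aromatic carbon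

Among the measured compounds shown here, with no measured step on chloro in place of methoxy, the expectation rests on compound 2 alone. The loss of the one hydrogen-bond acceptor of the methoxy on the 4-substituted ring is taken as a modest weakening, a step in this assay somewhat beyond the scatter, toward higher numbers. Compound 3 is therefore estimated at 45 nM, within 10 nM to 200 nM; the expected step is a 3.1-fold higher number from compound 2 to compound 3 (0.49 log units; beyond the scatter). A result within the scatter of compound 2 is not excluded.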

Compound 3, half-maximal inhibitory concentration: 23.6 nM
Beside the measured number, compound 3's estimate is 1.9-fold (0.28 log units) above it; the measured number falls inside the stated range.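

In this assay the exchange of 4-methoxyphenyl for 4-chlorophenyl gives a 1.6-fold higher number from compound 2 to compound 3 (0.21 log units; within the scatter) and so leaves the read-out unresolved from that of the methoxy compound. Among these compounds, this is the first step, and it shows that this position accepts chloro in place of methoxy without a difference that can be read. The pair also shows that the hydrogen-bond acceptor and the extra heavy atom of the methoxy are not needed to keep the number within the scatter, at least for this one replacement. No measured evidence bears on why the two compounds read alike.

Steps involving compound 1 cannot be read, so the fluoro analogue adds nothing yet. On these data alone, whether an amine, a carboxylic acid or a longer alkoxy chain at this position would hold the number stays open.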